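A few compounds are considered here, and "the series" means these few. Any claim that something is new, unique, unknown or untested is made for them only; others in the source may bear on it.

Working notes on the series. Three compounds have been run in a toxicity assay on BJ cells (Homo sapiens) for cytotoxicity, read by MTT assay, with a stated time of 24 h; a higher number here means a weaker inhibitor, a lower number a stronger inhibitor. Compound 1 `CCOC(=O)N1CCC(=NNC(=O)c2ccc(F)cc2)CC1` gives > 400000 nM, which is a limit of the assay rather than a number. Compound 2 `CCOC(=O)N1CCC(=NNC(=O)c2ccc([N+](=O)[O-])cc2[N+](=O)[O-])CC1` gives > 400000 nM, again a limit. Compound 3 `O=C(NN=C1CC(c2ccccc2)NC(c2ccccc2)C1)c1ccccc1` gives > 400000 nM, also a limit. For the measured compounds named here, all three results sit at the same point, described by the limit of > 400000 nM in this assay, at which 3 of the 3 values shown sit; no step between measured compounds can be counted, and nothing is therefore known about how any structural change moves the number in this assay. Compound 3 stands at the limit alongside the other two, with no number of its own to compare.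

Compound 4 `O=C(NN=C1CC(c2ccccc2)NC(c2ccccc2)C1)c1ccc([N+](=O)[O-])cc1` is not yet measured in this assay. It differs from compound 3 by nitro in place of hydrogen on an aromatic carbon. Going by the values given here, no measured step is available to size this change, and the expectation for compound 4 is a step of a number no higher from compound 3 to compound 4 (the limit leaves the size open), none beyond the scatter. Compound 4 is estimated at 400000 nM, with a range from 200000 nM to 800000 nM, and the result is most likely to come back once more as a limit rather than a number.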

Compound 4, half-maximal inhibitory concentration: > 400000 nM
Compound 4 was reported as a limit; the forecaster's own chance of this, stated with the estimate: 85%; the middle value sits exactly at the limit.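

Compound 4 gives > 400000 nM in this assay, again a limit. For the compounds shown here, compound 3 is a limit too, so no step from compound 3 to compound 4 can be read. The compounds shown leave open what number any structure here would give, and whether any structural change moves it, since all rest on one limit: the limit of > 400000 nM in this assay, at which 4 of the 4 values shown sit.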